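The source may hold more compounds than are shown below. What is called first, only, known or untested is meant among the compounds shown, and "the series" means these compounds.

Three compounds of the series share one core and differ only in the aryl group on a saturated chain carbon bound to a sulfur. Compound 1 `Cn1cc(SCc2nnc(SCc3c(Cl)cccc3Cl)n2-c2c(Cl)cccc2Cl)c2ccccc21` and compound 2 `Cn1cc(SCc2nnc(SCc3cccc(Cl)c3F)n2-c2c(Cl)cccc2Cl)c2ccccc21` open the set. In a toxicity assay on HEK-293T cells (Homo sapiens) for cytotoxicity, read by CCK-8 assay, with a stated time of 48 h (on this read-out higher numbers stand for lower toxicity in this test and lower numbers for higher toxicity in this test), compound 1 gives > 100000 nM, a limit of the assay. In this assay compound 2 gives > 100000 nM, again a limit of the assay. Among the compounds with values here, compound 3 `Cn1cc(SCc2nnc(SCc3ccc(Cl)cc3C(F)(F)F)n2-c2c(Cl)cccc2Cl)c2ccccc21` gives 56500 nM in this assay, the only number among the three, and the step of an at least 1.7-fold lower number from compound 1 to compound 3 (0.24 log units; that floor lies within the scatter) together with the step of an at least 1.7-fold lower number from compound 2 to compound 3 (0.24 log units; that floor lies within the scatter) are floors set by the limit of > 100000 nM in this assay, at which 2 of the 3 values shown sit. Compound 4 `Cn1cc(SCc2nnc(SCc3ccc(Cl)c(F)c3)n2-c2c(Cl)cccc2Cl)c2ccccc21` is not yet measured; it differs from compound 3 by 4-chloro-3-fluorophenyl in place of 4-chloro-2-(trifluoromethyl)phenyl on a saturated chain carbon bound to a sulfur. Those floored steps leave the effect of aryl changes at this place unresolved, so the expected step of a 1.6-fold higher number from compound 3 to compound 4 (0.20 log units; within the scatter) is small. For compound 4 a value of 90000 nM is expected, between 40000 nM and 200000 nM.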

Compound 4, half-maximal cytotoxic concentration: > 100000 nM
Compound 4 was reported as a limit; the forecaster's own chance of this, stated with the estimate: 50%; middle value at least 1.1-fold (0.04 log units) away from the limit.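

Replacing 4-chloro-2-(trifluoromethyl)phenyl with 4-chloro-3-fluorophenyl gives an at least 1.7-fold higher number from compound 3 to compound 4 (0.24 log units; that floor lies within the scatter) in this assay, so this change is not shown to move the read-out beyond the scatter. Within the data shown here, compound 4 is a third compound reported only as a limit, and compound 3 still holds the only number. The steps from compound 1 and from compound 2 to compound 4 cannot be read because both ends of each are limits: the limit of > 100000 nM in this assay, at which 3 of the 4 values shown sit.

From the compounds shown here alone, how far any of the limit compounds lies from compound 3 remains open. Also open, going by these compounds, is what an amine or a carboxylic acid in place of the aryl group would give at this place.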